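From amino to dimethylamino on compound 2

The source may hold more compounds than are shown below. What is called first, only, known or untested is meant among the compounds shown, and "the series" means these compounds.

Among the measured compounds shown here, in a functional assay on A549 cells (Homo sapiens) for antiproliferative activity, read by MTT assay, with a stated time of 48 h (a higher number here means a weaker inhibitor, a lower number a stronger inhibitor), compound 2 (`C=C(c1ccc(OC)cc1NC(=O)CN)c1ccc(OC)c2c1C=CC(C)(C)O2`) gives 90 nM and holds the lower of the two numbers so far, the stronger result, while compound 1 (`COc1ccc(C(=O)c2ccc(OC)c3c2OC(C)(C)C=C3)c(NC(=O)CN(C)C)c1`) gives 890 nM and lies beyond the scatter from it. Compound 3 (`C=C(c1ccc(OC)cc1NC(=O)CN(C)C)c1ccc(OC)c2c1C=CC(C)(C)O2`) has dimethylamino in place of amino on a saturated chain carbon bound to a carbonyl carbon. For the measured compounds named here, no measured pair isolates this change, so only a small move towards a higher number is expected, with a 1.3-fold higher number from compound 2 to compound 3 (0.12 log units; within the scatter) as the estimated step, within the scatter. For compound 3 the estimated value is 120 nM with a range from 35 nM to 400 nM as the expected span.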

Compound 3, half-maximal inhibitory concentration: 550 nM
Compound 3: the middle estimate sits 4.6-fold (0.66 log units) below what was measured; measured number outside the range, above it.
By their numbers in this assay, from the lowest: compound 2; then compounds 3 and 1 (each within the scatter of the next).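

In this assay, dimethylamino in place of amino on a saturated chain carbon bound to a carbonyl carbon gives a 6.1-fold higher number from compound 2 to compound 3 (0.79 log units; beyond the scatter) and so weakens the result. Among the compounds shown here, this is the first pair to isolate this position, and it shows that the position responds to a change of only a few atoms. No evidence here explains the rise. Methylamino at this position could show whether a single added methyl carries the same step, and the compounds shown leave open how a longer chain would fare.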